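The source may hold more compounds than are shown below. What is called first, only, known or untested is meant among the compounds shown, and "the series" means these compounds.

Measured compounds:
- compound 2, `Cc1nc(N)sc1CCCN/C(N)=N/C(=O)NC1CCCCC1`: 0.43
- compound 3, `Cc1nc(N)sc1CCCN/C(N)=N/C(=S)N[C@H](C)c1ccccc1`: 0.11
- compound 1, `N/C(=N\C(=O)NC1CCCCC1)Nc1cccc(-c2csc(N)n2)c1`: "not determined" (no result reported)

Among the measured compounds shown here, in a functional assay on HEK293T cells for agonist activity at histamine H2 receptor (Homo sapiens), read by beta-arrestin recruitment (a lower number here means a smaller maximal response, a higher number a larger maximal response), compound 2 gives 0.43, the higher of the two numbers known. Compound 3 gives 0.11, a value well beyond the usual scatter below compound 2. Compound 1 carries no number in this assay. Compound 4, `CCCNC(=O)/N=C(\N)NCCCc1sc(N)nc1C`, has not yet been measured. It differs from compound 2 in one place: propyl in place of cyclohexyl on an amide-type nitrogen. For the measured compounds named here, no pair of measured compounds shows this change, so there is no measured step to lean on; compound 3 differs from compound 2 in more than one place and so tells nothing about the cyclohexyl to propyl swap on its own. Since the carbonyl, the guanidine-type chain and the core of compound 2 are kept, the expectation for compound 4 is a step of a number 0.030 lower from compound 2 to compound 4 (within the scatter), that is, no change beyond the scatter, with the outcome uncertain in either direction. The estimate for compound 4 in this assay is 0.4, with a range from 0.2 to 0.65.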

Compound 4, intrinsic activity: the largest response reached, as a fraction of the reference agonist's: 0.32
Beside the measured number, compound 4's estimate is 0.080 above it, within the range that was stated.
By their numbers in this assay, from the lowest: compound 3; then compound 4; then compound 2.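

In this assay, among the compounds shown here, replacing cyclohexyl with propyl on an amide-type nitrogen gives the first measured step at this place, a number 0.11 lower from compound 2 to compound 4 (beyond the scatter) in the maximal response. The ring is therefore not required for a response, since compound 4 still gives a measurable value (0.32), but the group on this nitrogen does affect how large that response is. The change removes the ring and shortens the carbon count together, and nothing given here explains the step.

The compounds shown leave open whether the ring or the number of carbons accounts for the step, a question that a hexyl chain or a cyclopropyl ring on the same nitrogen could address. They also leave open how a phenyl or benzyl group would behave at this place.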